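Compound 1 to compound 4: loss of (furan-2-yl)carbonyl

A few compounds are considered here, and "the series" means these few. Any claim that something is new, unique, unknown or untested is made for them only; others in the source may bear on it.

In an ADME assay on MAGI cells (Homo sapiens) for cytotoxicity (a lower number here means that less compound is tolerated, a higher number that more compound is tolerated), compound 1 (`NCCCCN(C[C@@H]1CN(C(=O)c2ccco2)CCN1)[C@H]1CCCc2cccnc21`) gives > 10 uM as a limit and not a number. Compound 2 (`NCCCCN(C[C@H]1CN(S(=O)(=O)c2ccc(Cl)cc2)CCN1)[C@H]1CCCc2cccnc21`) gives > 10 uM as a limit too. Compound 3 (`NCCCCN(C[C@H]1CN(C(=O)Nc2ccccc2)CCN1)[C@H]1CCCc2cccnc21`) likewise gives > 10 uM as a limit. The series thus shows the limit of > 10 uM in this assay, at which 3 of the 3 values shown sit, and compound 1 has no readable rank within it.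

Among the measured compounds shown here, compound 4 (`NCCCCN(C[C@@H]1CNCCN1)[C@H]1CCCc2cccnc21`) comes from compound 1 through hydrogen in place of (furan-2-yl)carbonyl on an amine nitrogen in a ring and has no measured value so far.

For the measured compounds named here, the only measured step that bears on this also exchanges a group on an amine nitrogen in a ring: it is a step that the two limits leave unreadable from compound 2 to compound 3 and gives neither a size nor a direction. A shift beyond the usual scatter in this assay is therefore not expected, though the data do not exclude one.

Compound 4 is estimated at 20 uM in this assay with an expected range of 8 uM to 60 uM around it. The expected change is a step that the limit leaves unreadable from compound 1 to compound 4 as an estimate only.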

Compound 4, half-maximal toxic concentration: > 10 uM
Compound 4: only a limit was reported (the forecaster's own chance of this, stated with the estimate: 70%); the middle value is on the limit's open side.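

In this assay compound 4 gives > 10 uM, which is a limit and not a number. Compound 1 also carries only a limit, so the change between compound 1 and compound 4 cannot be read. The compounds shown leave open whether any of them differs from another, and the series offers only one reading: the limit of > 10 uM in this assay, at which 4 of the 4 values shown sit.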